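Chloro-fused aminopyrimidine core: neopentyl and benzamide variants

A few compounds are considered here, and "the series" means these few. Any claim that something is new, unique, unknown or untested is made for them only; others in the source may bear on it.

The measured compounds: compound 1 `Cn1cc2c(Cl)nc(NC(=O)c3ccc(C(F)(F)F)cc3)nc2n1` gives > 100000 nM; compound 2 `CC(C)(C)Cn1cc2c(Cl)nc(N)nc2n1` gives 12000 nM; compound 3 `Cn1cc2c(Cl)nc(N)nc2n1` gives 29700 nM.

All three were tested in an assay on CHO cells for displacement of a labelled ligand from adenosine receptor A1 (Homo sapiens), read by scintillation counting, with a stated time of 3 h; a higher number here means a weaker inhibitor, a lower number a stronger inhibitor. Compound 3 is the smallest member, bearing a free amine on the shared core. Compound 2 carries the change (tert-butyl in place of hydrogen on a saturated chain carbon bound to an aromatic nitrogen), and this step reads a 2.5-fold lower number from compound 3 to compound 2 (0.39 log units; beyond the scatter). For compound 1 the value is a limit of the assay and not a number, as the line the limit of > 100000 nM in this assay, at which 1 of the 3 values shown sits, shows. How the core of compound 1 differs from the core of compound 3 is not broken down here.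

Compound 4 `CC(C)(C)Cn1cc2c(Cl)nc(NC(=O)c3ccc(C(F)(F)F)cc3)nc2n1` has not yet been measured. It differs from compound 1 by tert-butyl in place of hydrogen on a saturated chain carbon bound to an aromatic nitrogen, which is the same change as that from compound 3 to compound 2, at the same place. Its expectation rests on two things: the modest step measured as a 2.5-fold lower number from compound 3 to compound 2 (0.39 log units; beyond the scatter), and the fact that compound 1 sits only at a limit in this assay, so there is no number from which a similar step could be counted downward. On that basis the expected step is a number no higher from compound 1 to compound 4 (the limit leaves the size open), set beside the earlier one, and there is a real chance that the result for compound 4 is again reported as a limit rather than a number. Compound 4 is therefore estimated at 100000 nM, with a range from 30000 nM to 300000 nM.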

Compound 4, inhibition constant: > 100000 nM
Compound 4: only a limit was reported; the forecaster's own chance of this, stated with the estimate: 60%; the middle value sits exactly at the limit.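

Compound 1 and compound 4 both stand only at a limit in this assay, so no step can be read between them: the limit of > 100000 nM in this assay, at which 2 of the 4 values shown sit.

The compounds shown leave open whether a 2.5-fold lower number from compound 3 to compound 2 (0.39 log units; beyond the scatter) has any counterpart once the free amine of the shared core is replaced by the amide of compound 1 and compound 4.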